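Variation at the chain carbon of compound 3

This account rests on a few compounds, and the source may have more. Where it says the series, first, only, none or still open, it means among the compounds named here.

Measured so far in a functional assay on CHO cells for antagonist activity at prostaglandin E2 receptor EP3 subtype (Homo sapiens), read by cAMP accumulation; a lower number here means a stronger inhibitor, a higher number a weaker inhibitor:
compound 1, `CC(C)C(Cc1ncc[nH]1)c1ccc(-c2ccc3cccc(F)c3c2)[nH]c1=O`: 76 nM
compound 2, `CC(C)C(c1ncco1)c1ccc(-c2ccc3cccc(F)c3c2)[nH]c1=O`: 64 nM
compound 3, `CC(C)C(c1ccc(-c2ccc3cccc(F)c3c2)[nH]c1=O)N1CCCCC1=O`: 40 nM

Compound 3 carries the lowest number of the three, but its steps from the others, a 1.9-fold lower number from compound 1 to compound 3 (0.28 log units; within the scatter) and a 1.6-fold lower number from compound 2 to compound 3 (0.20 log units; within the scatter), both lie within the scatter, so no order among the three can be read. Compound 4, `CC(C)C(c1ccc(-c2ccc3cccc(F)c3c2)[nH]c1=O)N1CCN/C1=N\C#N`, differs from compound 3 by a group of 8 heavy atoms (4 carbon, 4 nitrogen; one five-membered non-aromatic ring with 2 hetero atoms) in place of a group of 7 heavy atoms (5 carbon, 1 nitrogen, 1 oxygen; one six-membered non-aromatic ring with 1 hetero atom), on a saturated chain carbon bound to an aromatic carbon and a saturated chain carbon. The changes that bear on this place are a 1.2-fold lower number from compound 1 to compound 2 (0.07 log units; within the scatter), a 1.9-fold lower number from compound 1 to compound 3 (0.28 log units; within the scatter) and a 1.6-fold lower number from compound 2 to compound 3 (0.20 log units; within the scatter): three different groups on the same carbon, none moving this assay beyond the scatter. A fourth group at the same place is therefore expected to give no step beyond the scatter, i.e. an expected 1.1-fold higher number from compound 3 to compound 4 (0.05 log units; within the scatter). Compound 4 is estimated at 45 nM, with a range from 20 nM to 110 nM.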

Compound 4, half-maximal inhibitory concentration: 38 nM
The estimate for compound 4 lay 1.2-fold (0.07 log units) above the measured number; the measured number falls inside the stated range.
By their numbers in this assay, from the lowest: compounds 4, 3, 2 and 1 (each within the scatter of the next).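

In this assay the steps of a 1.1-fold lower number from compound 3 to compound 4 (0.02 log units; within the scatter) and a 1.7-fold lower number from compound 2 to compound 4 (0.23 log units; within the scatter) and a 2.0-fold lower number from compound 1 to compound 4 (0.30 log units; within the scatter) all stay within the scatter. This position therefore also accepts a group with a hydrogen-bond donor and a triple bond, neither of which the 2-oxopiperidin-1-yl group has, with no step beyond the scatter.

As far as these compounds go, whether an amine, a carboxylic acid or a longer chain on this carbon would stay within the scatter remains open, as does the role of the neighbouring isopropyl group. No measurement shown explains why these groups give such similar numbers.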